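Chain extension on the isothiocyanate linker, amide series

The source may hold more compounds than are shown below. What is called first, only, known or untested is meant among the compounds shown, and "the series" means these compounds.

Compound 1 `CN(C)C(=O)c1cc2cnc(Nc3ccc(S(=O)(=O)NCCCCCCN=C=S)cc3)nc2n1C1CCCC1` and compound 2 `CN(C)C(=O)c1cc2cnc(Nc3ccc(S(=O)(=O)NCCCCCCCN=C=S)cc3)nc2n1C1CCCC1` carry a sulfonamide linker; compound 3 `CN(C)C(=O)c1cc2cnc(Nc3ccc(C(=O)NCCCCCN=C=S)cc3)nc2n1C1CCCC1` and compound 4 `CN(C)C(=O)c1cc2cnc(Nc3ccc(C(=O)NCCCCCCN=C=S)cc3)nc2n1C1CCCC1` carry an amide-type linker. In a functional assay on NCI-H1299 cells (Homo sapiens) for inhibition, read by CCK-8 assay, with a stated time of 72 h, tested at 10 uM (on this read-out higher numbers stand for a stronger effect at the one concentration tested and lower numbers for a weaker effect), compound 1 gives 70.6%, compound 2 gives 83% and compound 3 gives 76.5%. The change a group of 4 heavy atoms (2 carbon, 1 nitrogen, 1 sulfur; no ring) in place of a group of 3 heavy atoms (1 carbon, 1 nitrogen, 1 sulfur; no ring), on a saturated chain carbon, six bonds along the chain from a sulfonamide nitrogen made the step of a number 12.4 percentage points higher from compound 1 to compound 2 (beyond the scatter). The difference between the two cores of compound 1 and compound 3 is not broken down here. Compound 4 differs from compound 3 by a group of 4 heavy atoms (2 carbon, 1 nitrogen, 1 sulfur; no ring) in place of a group of 3 heavy atoms (1 carbon, 1 nitrogen, 1 sulfur; no ring), on a saturated chain carbon, five bonds along the chain from an amide-type nitrogen; the place differs from the earlier one, five bonds along the chain from an amide-type nitrogen rather than six bonds from a sulfonamide nitrogen, so this is the same kind of change, not the same. Among the measured compounds shown here, the expected step is a number 7.5 percentage points higher from compound 3 to compound 4 (within the scatter), resting on the single precedent a number 12.4 percentage points higher from compound 1 to compound 2 (beyond the scatter). Compound 4 is estimated at 84%, between 72% and 94%.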

Compound 4, a percentage reported as inhibition, at one concentration (the size of the read-out at that concentration, not a potency): 85%
The estimate for compound 4 lay 1 percentage points below the measured number, and the stated range covers the measured number.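

In this assay, the one-carbon chain extension on the amide-type linker gives a number 8.5 percentage points higher from compound 3 to compound 4 (within the scatter). This rests on a single pair per linker at one concentration, so it sets no general rule for other cores and does not establish a real gain on the amide-type linker taken alone. Even so, the change carries from the sulfonamide pair to the amide-type pair with no detectable difference in the size of the step: the same change on two cores in this assay, a number 12.4 percentage points higher (beyond the scatter) from compound 1 to compound 2 and a number 8.5 percentage points higher (within the scatter) from compound 3 to compound 4, 3.9 percentage points apart, within the scatter of two such steps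

The compounds shown leave open whether a longer chain would give a further rise on either linker. They also leave open how inhibition responds when an acrylamide or a plain amine takes the place of the isothiocyanate.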